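From Trifluoromethyl to Triazole on a Shared Core

A few compounds are considered here, and "the series" means these few. Any claim that something is new, unique, unknown or untested is made for them only; others in the source may bear on it.

Compound 3, `COc1ccc(-c2cc(-c3ccc(C(F)(F)F)cc3)cnc2N)cn1`, stands highest of the three compounds measured in a physicochemical assay for lipophilicity, at pH 7.4 (on this read-out lower numbers stand for lower lipophilicity and higher numbers for higher lipophilicity), giving 4.2. Compound 1, `CNS(=O)(=O)c1ccc(-c2cnc(N)c(-c3ccc(OC)nc3)c2)cc1`, gives 2.2 in this assay, and compound 2, `COc1ccc(-c2cc(-c3ccc(S(N)(=O)=O)cc3)cnc2N)cn1`, gives 1.8. Both steps that lead to compound 3 are large: a number 2.00 log units higher from compound 1 to compound 3 (beyond the scatter) and a number 2.40 log units higher from compound 2 to compound 3 (beyond the scatter). By comparison, the step of a number 0.40 log units lower from compound 1 to compound 2 (beyond the scatter) is modest.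

Compound 4, `COc1ccc(-c2cc(-c3ccc(-n4cncn4)cc3)cnc2N)cn1`, differs from compound 3 in one place: 1H-1,2,4-triazol-1-yl in place of trifluoromethyl on an aromatic carbon. Among the measured compounds shown here, no measured step covers this exact exchange. What bears on it is that replacing trifluoromethyl on that same aromatic carbon with a group carrying hydrogen-bond acceptors, read in reverse from the steps to compound 1 and compound 2, gave large drops in this assay. The entering 1H-1,2,4-triazol-1-yl carries three hydrogen-bond acceptors but no donor, so a drop is expected, though smaller than those two. Compound 4 is expected to give 2.7, within a range from 2 to 3.4. This corresponds to an expected step of a number 1.50 log units lower from compound 3 to compound 4 (beyond the scatter).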

Compound 4, distribution coefficient: 2.4
The estimate for compound 4 lay 0.30 log units above the measured number; the range from low to high includes it.
By their numbers in this assay, from the lowest: compound 2; then compounds 1 and 4 (each within the scatter of the next); then compound 3.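

Putting 1H-1,2,4-triazol-1-yl in place of trifluoromethyl gives a step of a number 1.80 log units lower from compound 3 to compound 4 (beyond the scatter) in this assay and so shows that a large drop at this position does not require a sulfonamide group, since the entering group has no hydrogen-bond donors. The new group also separates the two sulfonamide compounds: the exchange for sulfamoyl is a clear step of a number 0.60 log units higher from compound 2 to compound 4 (beyond the scatter) while the exchange for methylsulfamoyl is a step of a number 0.20 log units higher from compound 1 to compound 4 (within the scatter) and so cannot be told apart. Nothing available here explains why these groups stand where they do.

The compounds shown leave open where an amine, a carboxylic acid or a nitrile would stand at this position. They also leave open whether an imidazol-1-yl ring would stand close to compound 4, and whether the exchange would give a similar step on another core.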